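Rearranging a Branched Side Chain: Compound 2 to Compound 4

A few compounds are considered here, and "the series" means these few. Any claim that something is new, unique, unknown or untested is made for them only; others in the source may bear on it.

Compound 1 `CC(C)(C)/N=C(\NC#N)Nc1ccc(Cl)nc1Cl`: in a functional assay on the whole organism (blood, strain Wistar-Okamoto) with Rattus norvegicus as the target, with a stated time of 5 days (on this read-out higher numbers stand for an effect only at larger amounts of compound and lower numbers for an effect already at smaller amounts), compound 1 gives > 50 mg/kg, which is a limit of the assay and not a number.
Compound 2 `CCC(/N=C(\NC#N)Nc1ccncc1)C(C)C`: in this assay compound 2 gives 5 mg/kg.
Compound 3 `CC(C)C(/N=C(\NC#N)Nc1ccncc1)C(C)C`: in this assay compound 3 gives 8 mg/kg.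

Compound 2 holds the lowest of the two numbers shown; its nearest neighbour is compound 3, and the step of a 1.6-fold higher number from compound 2 to compound 3 (0.20 log units; within the scatter) lies within the scatter. Compound 4 `CCC(C)(CC)/N=C(\NC#N)Nc1ccncc1` differs from compound 2 only in the branched saturated group: 1-ethyl-1-methylpropyl in place of 1-isopropylpropyl on a double-bonded nitrogen. Among the compounds with values here, the one measured step that bears on this change, a 1.6-fold higher number from compound 2 to compound 3 (0.20 log units; within the scatter), also alters that saturated chain and stays within the scatter. Compound 4 is therefore expected to show no step beyond the scatter, a 1.2-fold higher number from compound 2 to compound 4 (0.08 log units; within the scatter). The estimate for compound 4 is 6 mg/kg, with a range from 2.5 mg/kg to 15 mg/kg.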

Compound 4, minimum effective dose: 0.5 mg/kg
The estimate for compound 4 lay 12-fold (1.08 log units) above the measured number, and the stated range ends above it.
By their numbers in this assay, from the lowest: compound 4; then compounds 2 and 3 (each within the scatter of the next). At a limit, above all of these: compound 1.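

Exchanging 1-isopropylpropyl for 1-ethyl-1-methylpropyl on the double-bonded nitrogen gives a 10-fold lower number from compound 2 to compound 4 (1.00 log units; beyond the scatter) in this assay, although the two groups have the same count of carbons. The earlier change in this chain, a 1.6-fold higher number from compound 2 to compound 3 (0.20 log units; within the scatter), had not moved the number beyond the scatter, whereas this one shows that rearranging the same saturated carbons at this place can do so. Nothing among the data shown accounts for this step.

On these data alone, it remains open how a cyclopentyl ring or a longer chain would fare at this place, and whether the step carries over to another core.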